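Chloro substitution on the aniline ring of compound 2

The source may hold more compounds than are shown below. What is called first, only, known or untested is meant among the compounds shown, and "the series" means these compounds.

Measured compounds:
compound 1 `Cc1cc(Nc2ncc(Cl)c(Nc3cn(C)nc3S(=O)(=O)C(C)C)n2)c(OC(C)C)cc1C1CCNC1`: 364 nM
compound 2 `CC(C)S(=O)(=O)c1nn(C)cc1Nc1nc(Nc2ccc(C3CCN(C)CC3)cc2OC2CC2)ncc1Cl`: 36 nM
compound 3 `Cc1cc(Nc2ncc(Cl)c(Nc3cn(C)nc3S(=O)(=O)C(C)C)n2)c(C(F)(F)F)cc1C1CCN(C)CC1`: 1080 nM

In a functional assay on NCI-H2228 cells (Homo sapiens) for inhibition, read by CellTiter-Glo, with a stated time of 96 h (on this read-out lower numbers stand for stronger inhibition and higher numbers for weaker inhibition), compound 2 gives the lowest number of the three, with compound 1 higher and compound 3 higher still, both gaps beyond the scatter. Among the compounds with values here, no single-change pair among the measured compounds exists, so the effect of a lone substituent on the aniline ring cannot be read from them.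

Compound 4 `CC(C)S(=O)(=O)c1nn(C)cc1Nc1nc(Nc2cc(Cl)c(C3CCN(C)CC3)cc2OC2CC2)ncc1Cl` differs from compound 2 by chloro in place of hydrogen on an aromatic carbon. The expected step from compound 2 to compound 4 is a modest loss, a 1.5-fold higher number from compound 2 to compound 4 (0.18 log units; within the scatter), and may fall within the scatter. Compound 4 is estimated at 55 nM, in the range 18 nM to 170 nM.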

Compound 4, half-maximal inhibitory concentration: 103 nM
Estimate against measurement, compound 4: 1.9-fold (0.27 log units) below; measured number inside the range.
By their numbers in this assay, from the lowest: compound 2; then compound 4; then compound 1; then compound 3.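

In this assay, within the data shown here, chloro in place of hydrogen on the aromatic carbon ortho to the 1-methylpiperidin-4-yl group and para to the cyclopropyloxy group gives a 2.9-fold higher number from compound 2 to compound 4 (0.46 log units; beyond the scatter), the first single-change step. This position is therefore sensitive to one added chlorine atom, though the loss is modest. Nothing measured here bears on the reason for this step.

As far as these compounds go, whether fluoro, methoxy or nitrile on this same carbon would give a smaller or larger step stays open. So does whether the chloro step holds with another group in place of cyclopropyloxy.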